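Swapping the aryl group on the shared core: compound 1 to compound 3

The source may hold more compounds than are shown below. What is called first, only, known or untested is meant among the compounds shown, and "the series" means these compounds.

Compound 1 `Cc1cc(F)cc(Nc2cc(NC(=O)Nc3c(Cl)cccc3Cl)ncn2)c1` was tested in a functional assay on PC-9 cells (Homo sapiens) for inhibition, read by MTT assay, with a stated time of 48 h, tested at 10 uM (a higher number here means more inhibition at the concentration tested (going by the name of the read-out), a lower number less inhibition), and gives 80%. Its companion, compound 2 `COc1cc(NC(=O)Nc2cc(Nc3ccc(C)c(F)c3)ncn2)cc(OC)c1`, gives 77.5% in this assay, so the two numbers lie within the usual scatter of each other and neither can be called stronger. Compound 3 `CCc1ccc(Nc2cc(NC(=O)Nc3c(Cl)cccc3Cl)ncn2)cc1` is not yet measured. It differs from compound 1 in one place: 4-ethylphenyl in place of 3-fluoro-5-methylphenyl on a nitrogen on an aromatic ring. For the measured compounds named here, no measured pair shows what this kind of change does, so the size of the step is uncertain. Compound 3 is expected to stay close to compound 1, with a small drop of a number 8 percentage points lower from compound 1 to compound 3 (within the scatter) in this assay, giving an estimate of 72%, between 50% and 90%.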

Compound 3, a percentage reported as inhibition, at one concentration (the size of the read-out at that concentration, not a potency): 70.1%
Beside the measured number, compound 3's estimate is 1.9 percentage points above it; the range from low to high includes it.
By their numbers in this assay, from the lowest: compounds 3, 2 and 1 (each within the scatter of the next).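

Putting 4-ethylphenyl in place of 3-fluoro-5-methylphenyl on this nitrogen gives a number 9.9 percentage points lower from compound 1 to compound 3 (within the scatter) in this assay. This first step at the position shows that an aryl group without fluorine, carrying a single ethyl group, still leaves compound 3 within the scatter of compound 1. Nothing available explains this result.

A single step at one concentration does not show how potency responds to changes here. Also open, as far as these compounds go, is whether an amine, a carboxylic acid or a longer chain on this phenyl ring would keep the inhibition.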